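The compounds below may be only part of what the source reports. "The series", "measured", "known", "first", "only" and "open" are said of these compounds alone.

Among the compounds with values here, compound 2, `CC(C(=O)NCc1ccc(C(F)(F)F)nc1N1CC=CCC1)c1ccc(NS(C)(=O)=O)c(F)c1`, is the only member of this set for which a number exists in a functional assay on CHO-K1 cells for antagonist activity at transient receptor potential cation channel subfamily V member 1 (Homo sapiens), read by FLIPR; a higher number here means a weaker inhibitor, a lower number a stronger inhibitor: compound 2 gives 0.3 nM. Within the data shown here, its companion compound 1, `CC(C(=O)NCc1ccc(C(F)(F)F)nc1NCc1cccnc1)c1ccc(NS(C)(=O)=O)c(F)c1`, which carries a different substituent at the same position of the shared core, is recorded in this assay as "not active" (no number reported), with no figure attached, so no step between the two can be counted.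

Compound 3, `CC(C(=O)NCc1ccc(C(F)(F)F)nc1N1CCC(O)CC1)c1ccc(NS(C)(=O)=O)c(F)c1`, is the next compound to be tested. It differs from compound 2 in one place: a group of 7 heavy atoms (5 carbon, 1 nitrogen, 1 oxygen; one six-membered non-aromatic ring with 1 hetero atom) in place of a group of 6 heavy atoms (5 carbon, 1 nitrogen; one six-membered non-aromatic ring with 1 hetero atom), on an aromatic carbon. The change keeps the six-membered non-aromatic ring with one hetero atom on the aromatic carbon next to the ring nitrogen, removes the double bond outside aromatic rings, and adds a hydroxyl group that brings one hydrogen-bond donor and a second hydrogen-bond acceptor.

Among the measured compounds shown here, with no measured step between two numbered compounds to lean on, the expectation for compound 3 in this assay rests on the single value of compound 2, 0.3 nM, and on the outcome for compound 1, "not active" (no number reported), which shows that this position can tolerate only some substituents. A modest loss of potency is expected, and compound 3 is estimated at 1 nM, with a likely range from 0.2 nM to 6 nM, a step of a 3.3-fold higher number from compound 2 to compound 3 (0.52 log units; beyond the scatter) that is expected to be no more than slightly beyond the scatter.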

Compound 3, inhibition constant: "not active" (no number reported)
No number was reported for compound 3, and the estimate cannot be compared.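

Compound 3, like compound 1, carries no number in this assay, so no step can be read from compound 2 to compound 3. Nothing shown here bears on the cause of this result. The compounds shown leave open whether the outcome for compound 3 follows from its hydroxyl group or from the lost double bond, since both change together.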